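Sulfamoyl on the Ring Nitrogen: Expected Shift in Cytotoxicity

This account rests on a few compounds, and the source may have more. Where it says the series, first, only, none or still open, it means among the compounds named here.

Three measured compounds share one core and differ only at a six-membered non-aromatic ring with two nitrogens. Compound 2 `Cc1cc(/C=C/C#N)cc(C)c1Oc1nc(Nc2ccc(CN3CCNCC3)cc2)nc2sccc12` carries this ring through a methylene link, with a free ring nitrogen. Compound 3 `Cc1cc(/C=C/C#N)cc(C)c1Oc1nc(Nc2ccc(N3CCNCC3)cc2)nc2ccsc12` attaches the same ring directly to the aromatic ring, again with a free nitrogen, and compound 1 `Cc1cc(/C=C/C#N)cc(C)c1Oc1nc(Nc2ccc(N3CCN(S(N)(=O)=O)CC3)cc2)nc2ccsc12` is compound 3 with a sulfamoyl group on that nitrogen.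

In an ADME assay on MT4 cells (Homo sapiens) for cytotoxicity, read by MTT assay, with a stated time of 5 days (on this read-out higher numbers stand for lower toxicity in this test and lower numbers for higher toxicity in this test), compound 2 gives 4030 nM, the smaller of the two numbers shown. Compound 3 gives 5730 nM, but its gap to compound 2 is within the scatter, so the two cannot be told apart. For compound 1 the result is a limit, > 222000 nM, not a number. Compound 1 thus sits at the limit of > 222000 nM in this assay, at which 1 of the 3 values shown sits. Going by the values given here, the one comparable step is an at least 38-fold lower number from compound 1 to compound 3 (1.58 log units; beyond the scatter), which shows that taking the sulfamoyl group away makes the number fall sharply.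

Compound 4 `Cc1cc(/C=C/C#N)cc(C)c1Oc1nc(Nc2ccc(CN3CCN(S(N)(=O)=O)CC3)cc2)nc2sccc12` is compound 2 with the reverse change, (sulfamoyl in place of hydrogen on an amine nitrogen in a ring). Because an at least 38-fold lower number from compound 1 to compound 3 (1.58 log units; beyond the scatter) ran the other way with this same group, a large rise in the number is expected, quite possibly beyond the limit of this assay. Compound 4 is therefore estimated at 200000 nM, within 40000 nM to 1000000 nM, an expected step of a 50-fold higher number from compound 2 to compound 4 (1.70 log units; beyond the scatter).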

Compound 4, half-maximal cytotoxic concentration: > 217000 nM
Compound 4: only a limit was reported; the forecaster's own chance of this, stated with the estimate: 55%; middle value at least 1.0-fold (0.03 log units) away from the limit.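

In this assay, changing (piperazin-1-yl)methyl to (4-sulfamoylpiperazin-1-yl)methyl gives an at least 53-fold higher number from compound 2 to compound 4 (1.73 log units; beyond the scatter), so a sulfamoyl group on the ring nitrogen again goes with a much higher number, which here stands for lower toxicity in this test. This time, the ring is held on a methylene link and sits on the core of compound 2, so the large shift is no longer tied to the core of compound 1 or to a directly attached ring. The change can now be compared on two cores: the same change on two cores in this assay, an at least 38-fold lower number (1.58 log units; beyond the scatter) from compound 1 to compound 3 and an at least 53-fold lower number (1.73 log units; beyond the scatter) from compound 4 to compound 2; the limit leaves it open whether they differ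

Going by these compounds, neither compound with the sulfamoyl group has an exact number, so how high the values truly lie, and how much the two steps might differ, remains unknown. On these data alone, it also remains open whether another group on the same ring nitrogen, such as acetyl or methyl, would shift the number as far, and whether a longer chain in place of the methylene link would keep the step this large.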